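Taking the benzyl group off compound 3

The compounds below may be only part of what the source reports. "The series", "measured", "known", "first", "only" and "open" are said of these compounds alone.

In a functional assay on MCF7 cells (Homo sapiens) for cytotoxicity, read by MTT assay, with a stated time of 6 days (a lower number here means that less compound is needed, a higher number that more compound is needed for the effect), compound 3 (`COC(=O)c1c(-c2ccc(OCc3ccccc3)cc2)oc2ccc(OC)cc2c1=O`) gives > 25 ug/mL as a limit and not a number. Compound 1 (`COC(=O)c1c(-c2ccc([N+](=O)[O-])cc2)oc2cc(OC)ccc2c1=O`) gives > 25 ug/mL as a limit too. Compound 2 (`COC(=O)c1c(-c2ccc(OCc3ccccc3)cc2)oc2ccccc2c1=O`) also gives > 25 ug/mL as a limit. The evidence so far is the limit of > 25 ug/mL in this assay, at which 3 of the 3 values shown sit, and nothing finer. Compound 4 (`COC(=O)c1c(-c2ccc(O)cc2)oc2ccc(OC)cc2c1=O`) has hydrogen in place of benzyl on an oxygen on an aromatic ring and so reads benzyloxy to hydroxy. Going by the values given here, the only measured step (a step that the two limits leave unreadable from compound 2 to compound 3) concerns methoxy in place of hydrogen and has no readable size. The estimated step (a number no higher from compound 3 to compound 4 (the limit leaves the size open)) is therefore expected to stay within the scatter, in neither direction. In this assay compound 4 is expected at 25 ug/mL with a range from 10 ug/mL to 50 ug/mL as an estimate.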

Compound 4, concentration for half-maximal effect: > 25 ug/mL
Compound 4 was reported as a limit; the forecaster's own chance of this, stated with the estimate: 65%; the middle value sits exactly at the limit.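

Compound 3 and compound 4 both stand only as limits in this assay, so the step from benzyloxy to hydroxy cannot be read. The compounds shown leave open how much of any of them the effect needs: the limit of > 25 ug/mL in this assay, at which 4 of the 4 values shown sit.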